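Swapping benzyl for pyridin-2-yl on the shared core

The source may report more compounds than this note shows. Statements on the series, on what has been measured and on what is new or still open speak of the compounds shown alone.

Measured in a functional assay on Jurkat cells (Homo sapiens) for inhibition, read by CCK-8 assay, with a stated time of 48 h; on this read-out higher numbers stand for weaker inhibition of growth and lower numbers for stronger inhibition of growth:
- Compound 1 `Cc1ccccc1Nc1nc(Nc2cccnc2)ncc1Cl`: 38600 nM
- Compound 2 `Cc1ccccc1Nc1nc(NC2CC2)ncc1Cl`: > 100000 nM (a limit)
- Compound 3 `Cc1ccccc1Nc1nc(NCc2ccccc2)ncc1Cl`: > 100000 nM (a limit)

Compound 3 gives > 100000 nM, which is a limit of the assay and not a number. Within the data shown here, its place is shared, since the series so far sits mostly at the limit of > 100000 nM in this assay, at which 2 of the 3 values shown sit. Compound 4 `Cc1ccccc1Nc1nc(Nc2ccccn2)ncc1Cl` differs from it in one place: pyridin-2-yl in place of benzyl on a nitrogen on an aromatic ring.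

Among the measured compounds shown here, three measured steps bear on this change. The closest is an at least 2.5-fold higher number from compound 1 to compound 3 (0.41 log units; beyond the scatter), where benzyl takes the place of pyridin-3-yl. Similar in size is an at least 2.5-fold higher number from compound 1 to compound 2 (0.41 log units; beyond the scatter), with cyclopropyl entering instead. By contrast, a step that the two limits leave unreadable from compound 2 to compound 3 says nothing on size. For the measured compounds named here, compound 1, at 38600 nM, is the only compound with a number, and it carries a pyridinyl group, as compound 4 does. A modest step to a lower number is therefore expected, though compound 4 may also stay at the limit.

The estimated step is an at least 2.0-fold lower number from compound 3 to compound 4 (0.30 log units; that floor lies within the scatter). For compound 4 the expected value is 50000 nM, with an estimated range of 18000 nM to 100000 nM.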

Compound 4, concentration for 50% growth inhibition: 20100 nM
Beside the measured number, compound 4's estimate is 2.5-fold (0.40 log units) above it; the measured number falls inside the stated range.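

In this assay the pyridin-2-yl group brings a clear gain over both non-pyridinyl groups, with an at least 4.9-fold lower number from compound 3 to compound 4 (0.69 log units; beyond the scatter) and with an at least 4.9-fold lower number from compound 2 to compound 4 (0.69 log units; beyond the scatter). Both steps are only floors, since compound 2 and compound 3 each stand at a limit and not at a number: the limit of > 100000 nM in this assay, at which 2 of the 4 values shown sit.

Among the compounds shown, only the two carrying a pyridinyl group give numbers, and exchanging pyridin-3-yl for pyridin-2-yl makes no readable difference, with a 1.9-fold lower number from compound 1 to compound 4 (0.28 log units; within the scatter).

From the compounds shown here alone, whether a plain phenyl group on that nitrogen would also give a number stays open, so the part played by the ring nitrogen remains unsettled. Also open, going by these compounds, is how pyridin-4-yl, or a methoxy group on the pyridine ring, would compare.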